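The source may hold more compounds than are shown below. What is called first, only, known or untested is meant among the compounds shown, and "the series" means these compounds.

Of the compounds shown here, two built on a shared core have been measured in a functional assay on K562 cells (Homo sapiens) for cytotoxicity, read by MTT assay, with a stated time of 72 h; a higher number here means a weaker inhibitor, a lower number a stronger inhibitor. Compound 1 `CC1=CCC[C@H]2[C@](C)(CC3=CC(=O)C=C(N[C@@H](CC(C)C)C(=O)O)C3=O)[C@@H](C)CC[C@]12C` gives 11200 nM, and compound 2 `CC1=CCC[C@H]2[C@](C)(CC3=CC(=O)C=C(NCC(=O)O)C3=O)[C@@H](C)CC[C@]12C` gives 15600 nM. These two values lie within the scatter of each other, so compound 2 cannot be ranked apart from compound 1 on these numbers. Compound 3 `CC1=CCC[C@H]2[C@](C)(CC3=CC(=O)C=C(N[C@@H](C(=O)O)C(C)C)C3=O)[C@@H](C)CC[C@]12C` has not yet been measured. It differs from compound 2 by isopropyl in place of hydrogen on a saturated chain carbon bound to an amine nitrogen and a carbonyl carbon, which means isopropyl in place of hydrogen on a saturated chain carbon bound to an amine nitrogen and a carbonyl carbon. For the measured compounds named here, only one measured step bears on this change. At the same place, isobutyl gives way to hydrogen in a 1.4-fold higher number from compound 1 to compound 2 (0.14 log units; within the scatter), and that step stays within the scatter. No measurement covers isopropyl itself, so this evidence is thin, but it gives no reason to expect a step beyond the scatter in this assay. The expected change is a 1.2-fold lower number from compound 2 to compound 3 (0.08 log units; within the scatter), which is an estimate within the scatter. For compound 3 the estimated value is 13000 nM, with an expected range of 7000 nM to 24000 nM.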

Compound 3, half-maximal inhibitory concentration: 7780 nM
The estimate for compound 3 lay 1.7-fold (0.22 log units) above the measured number; low and high end bracket the measured number.
By their numbers in this assay, from the lowest: compounds 3, 1 and 2 (each within the scatter of the next).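

In this assay isopropyl in place of hydrogen on a saturated chain carbon bound to an amine nitrogen and a carbonyl carbon gives a 2.0-fold lower number from compound 2 to compound 3 (0.30 log units; within the scatter) and so adds a second group at this place, with a step that does not leave the scatter. Putting 1-carboxy-2-methylpropyl in place of 1-carboxy-3-methylbutyl on an amine nitrogen gives a 1.4-fold lower number from compound 1 to compound 3 (0.16 log units; within the scatter) and so does not separate these two groups either, which means that hydrogen, isobutyl and isopropyl at this place cannot be ranked on these numbers. Nothing measured alongside these values offers an explanation for them.

The compounds shown leave open whether a group of another kind on this chain carbon, such as benzyl or a hydroxymethyl group, would produce a step beyond the scatter. They also leave open what would follow if a methyl ester or a primary amide stood in place of the carboxylic acid, since every compound here carries that acid.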